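Capping a Hydroxy Group with Methyl: What to Expect

A few compounds are considered here, and "the series" means these few. Any claim that something is new, unique, unknown or untested is made for them only; others in the source may bear on it.

Of the compounds shown here, two sharing one core have been measured in a functional assay on OVCAR-3 cells (Homo sapiens) for inhibition, read by sulforhodamine B assay, with a stated time of 48 h, tested at 100 uM; a lower number here means a stronger effect, a higher number a weaker effect of the compound at the concentration tested. Compound 1 `O=C(Nc1cccc(-n2cc(-c3ccncc3)c(-c3cc(O)cc(Cl)c3)n2)c1)Nc1ccc(Cl)c(C(F)(F)F)c1` gives -1% in this assay. Compound 2 `O=C(Nc1cccc(-n2cc(-c3ccncc3)c(-c3cc(O)cc(Cl)c3)n2)c1)Nc1ccc(Cl)c(Cl)c1` differs from it only by a chloro in place of the trifluoromethyl on an aromatic carbon, and in this assay compound 2 gives -20%. Going by the values given here, the single measured step is a number 19 percentage points lower from compound 1 to compound 2 (beyond the scatter), so compound 1 stands highest of the two numbers, with compound 2 beyond the scatter below it.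

Compound 3 `COc1cc(Cl)cc(-c2nn(-c3cccc(NC(=O)Nc4ccc(Cl)c(C(F)(F)F)c4)c3)cc2-c2ccncc2)c1` has not yet been measured. It differs from compound 1 in one place: methyl in place of hydrogen on an oxygen on an aromatic ring. Seen one bond further out, the hydroxy becomes a methoxy, and the 3-chloro-5-hydroxyphenyl becomes a 3-chloro-5-methoxyphenyl. Among the compounds with values here, no measured pair shows this kind of change. The step from compound 1 to compound 2 concerns a different part of the molecule and says nothing about putting a methyl on the oxygen. With no guidance either way, the expected step is no change at the digits printed from compound 1 to compound 3 (within the scatter), that is, nothing beyond the scatter. Compound 3 is therefore estimated to give -1% in this assay, with a likely range from -25% to 20%.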

Compound 3, a percentage reported as activity, at one concentration (the size of the read-out at that concentration, not a potency): -56%
Beside the measured number, compound 3's estimate is 55 percentage points above it; the whole stated range lies above it.
By their numbers in this assay, from the lowest: compound 3; then compound 2; then compound 1.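

In this assay, capping the hydroxy of the 3-chloro-5-hydroxyphenyl as a methoxy is far from a neutral swap: the change gives a number 55 percentage points lower from compound 1 to compound 3 (beyond the scatter), and a lower number here means a stronger effect at the concentration tested. Going by these compounds alone, this position on the oxygen therefore has a clear influence on the read-out, and the single methyl moves the number further than the swap elsewhere in the molecule, which gave a number 19 percentage points lower from compound 1 to compound 2 (beyond the scatter). Nothing measured here explains why this small change has such a large effect.

The compounds shown leave open whether the step belongs to the methyl itself or would also appear with an ethoxy, a longer chain on the oxygen, or an amine in the place of the hydroxy. Going by these compounds, they also leave open whether the same methyl would produce a similar step on compound 2, which carries chloro rather than trifluoromethyl, so it is unknown whether the two changes add together or whether each depends on the other.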